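A few compounds are considered here, and "the series" means these few. Any claim that something is new, unique, unknown or untested is made for them only; others in the source may bear on it.

Working notes on the urea series.

Of the compounds shown here, three have been measured in a functional assay on CHO cells for antagonist activity at C-X-C chemokine receptor type 3 (Homo sapiens), read by GTPgammaS binding; a lower number here means a stronger inhibitor, a higher number a weaker inhibitor. Compound 1 `O=C(Nc1c(Cl)cncc1Cl)NC1CCN(C/C2=C/CCCCCC2)CC1` gives 3400 nM in this assay. Compound 2 `O=C(Nc1ccc2ccccc2c1)NC1CCN(CCCc2ccccc2)CC1` gives 2200 nM in this assay. Compound 3 `CC1(C)[C@H]2CC=C(CN3CCC(NC(=O)Nc4ccccc4)CC3)[C@@H]1C2` gives 2000 nM in this assay. Compound 3 carries the lowest of the three numbers, but the gap to compound 2 and the gap to compound 1 both lie within the usual scatter of repeated measurements, so the three compounds cannot be told apart on these figures.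

The next compound to be measured is compound 4 `CC1(C)[C@H]2CC=C(CN3CCC(NC(=O)Nc4cc(F)cc(F)c4)CC3)[C@@H]1C2`. It differs from compound 3 in a single place: 3,5-difluorophenyl in place of phenyl on an amide-type nitrogen. Within the data shown here, no two measured compounds differ in this way, so there is no measured step to lean on for the size of the change, and the three measured numbers say nothing specific about substitution on the aryl ring of the urea.

With nothing in the series to anchor it, the change from compound 3 to compound 4 is expected to be small, leaning toward a somewhat lower number, and the step of a 1.5-fold lower number from compound 3 to compound 4 (0.19 log units; within the scatter) is an estimate that may well fall inside the scatter. Compound 4 is therefore expected to give about 1300 nM in this assay, with a range from 400 nM to 4500 nM.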

Compound 4, inhibition constant: 171 nM
Beside the measured number, compound 4's estimate is 7.6-fold (0.88 log units) above it; measured number outside the range, below it.
By their numbers in this assay, from the lowest: compound 4; then compounds 3, 2 and 1 (each within the scatter of the next).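

Among these compounds, the aryl ring on the urea proves to be a position that responds strongly in this assay: 3,5-difluorophenyl in place of phenyl on an amide-type nitrogen gives a 12-fold lower number from compound 3 to compound 4 (1.07 log units; beyond the scatter), the first step that can be read at all. The three earlier numbers could not be told apart and none of those compounds differed in a single place, so they gave no sign that one change could move the number this far. Here, two fluorine atoms entering the ring, with the rest of compound 3 unchanged, are enough to carry the number well past the scatter, though nothing measured on hand accounts for a step of this size.

The compounds shown leave open whether both fluorine atoms are needed, and whether a phenyl ring with a single fluorine, or with chlorine atoms, methoxy groups or nitrile groups in their place, would give a similar step. Going by these compounds, it also remains open whether 3,5-difluorophenyl would give a step of this size on the core of compound 1 or the core of compound 2.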